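This account rests on a few compounds, and the source may have more. Where it says the series, first, only, none or still open, it means among the compounds named here.

Measured so far:

Compound 1 `Nc1nc2ccccc2c(=O)[nH]1` gives 4.31 in an assay for inhibition of Dihydrofolate reductase (Homo sapiens); on this read-out higher numbers stand for higher potency (the scale is a negative logarithm) and lower numbers for lower potency.
Compound 2 `Nc1nc(N)c2c(S(=O)(=O)c3ccc(Cl)c(Cl)c3)cccc2n1` gives 4.24 in this assay.
Compound 3 `Nc1nc(O)c2c(Sc3ccc4ccccc4c3)cccc2n1` gives 6.15 in this assay.

Among these three numbers, compound 3 stands highest. Its nearest neighbour is compound 1, whose number lies below it by a margin beyond the scatter, and compound 2 lies still further below, also beyond the scatter. Compound 3 is therefore the most potent of the three measured compounds.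

The next compound, compound 4 `Nc1nc(N)c2c(Sc3ccc4ccccc4c3)cccc2n1`, shares the core and the naphthalene thioether of compound 3 and differs in a single place: amino in place of hydroxy on an aromatic carbon. Both the group that leaves and the group that enters carry one heavy atom, one hydrogen-bond donor and one hydrogen-bond acceptor, and neither carries a net charge.

Among the compounds with values here, no pair of measured compounds shows this exact change, so there is no measured step to lean on. Compound 2 also carries an amino group at this place, but it differs from compound 3 in other parts of the molecule as well, so its low number says little about the change alone. The expectation for compound 4 is an increase in this assay beyond the scatter, with the estimated step from compound 3 being a number 0.85 log units higher from compound 3 to compound 4 (beyond the scatter). Compound 4 is thus estimated at 7, within a range from 5.9 to 8.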

Compound 4, logarithm of the reciprocal of the active concentration, log(1/C): 6.92
Estimate against measurement, compound 4: 0.08 log units above, within the range that was stated.
By their numbers in this assay, from the lowest: compounds 2 and 1 (each within the scatter of the next); then compound 3; then compound 4.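

In this assay, placing amino instead of hydroxy on this aromatic carbon, opposite the ring nitrogen, gives a number 0.77 log units higher from compound 3 to compound 4 (beyond the scatter), the only step among the compounds shown that changes a single place. Compound 2 also carries amino here but differs from compound 3 elsewhere too, whereas this pair keeps the naphthalene thioether and the rest of the molecule the same, so the change can be read on its own. It shows that the number responds to which of these two groups sits at this position, even though they match in their counts of heavy atoms, hydrogen-bond donors and hydrogen-bond acceptors, and neither carries a net charge; nothing measured here speaks to what lies behind the step.

The compounds shown leave open how other groups at this position, such as methyl, methoxy or chlorine, would compare with amino and hydroxy. Within the data shown here, they also leave open whether the same change would give a similar step with another group in place of the naphthalene thioether, such as a phenyl thioether, as this single pair is the only reading of it.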